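Dimethylamino for ethoxy on compound 2

The source may report more compounds than this note shows. Statements on the series, on what has been measured and on what is new or still open speak of the compounds shown alone.

Measured so far in an ADME assay on J774 cells (Mus musculus) for cytotoxicity; on this read-out higher numbers stand for an effect only at larger amounts of compound and lower numbers for an effect already at smaller amounts:
Compound 1 `COC(=O)c1c[nH]c2cc(OCCOc3ccccc3)c(OC)cc2c1=O`: > 20000 nM
Compound 2 `CCCCc1cc2c(=O)c(C(=O)OCC)c[nH]c2cc1OCCOc1ccccc1`: > 20000 nM
Compound 3 `COC(=O)c1c[nH]c2cc(-c3ccccc3)ccc2c1=O`: > 20000 nM

Each of these entries is a limit of the assay and not a number, so the set shows (the limit of > 20000 nM in this assay, at which 3 of the 3 values shown sit). Compound 2 gives > 20000 nM, which is a limit as well. Compound 4 `CCCCc1cc2c(=O)c(C(=O)N(C)C)c[nH]c2cc1OCCOc1ccccc1` has dimethylamino in place of ethoxy on a carbonyl carbon, or ethoxycarbonyl to dimethylcarbamoyl (dimethylamino in place of ethoxy on a carbonyl carbon). Within the data shown here, no measured pair shows this change, so the expectation rests only on these limits. In this assay I expect no step beyond the scatter, in either direction, and the estimated change is a number no higher from compound 2 to compound 4 (the limit leaves the size open). The estimated value for compound 4 is 20000 nM, with an expected range of 10000 nM to 40000 nM.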

Compound 4, half-maximal effective concentration: 15300 nM
Compound 4: the middle estimate sits 1.3-fold (0.12 log units) above what was measured; low and high end bracket the measured number.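

In this assay compound 4 gives 15300 nM, a true number. The earlier compounds shown here gave only limits. Dimethylamino in place of ethoxy on a carbonyl carbon therefore gives an at least 1.3-fold lower number from compound 2 to compound 4 (0.11 log units; that floor lies within the scatter). The real size of this step stays unknown because compound 2 sits at a limit, so the change may be larger than that floor: the limit of > 20000 nM in this assay, at which 3 of the 4 values shown sit.

The compounds shown leave open how a carboxylic acid on this carbon would read in this assay. The same holds for a larger amine such as diethylamino.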